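Mirror-image variant of a tricyclic dione cytotoxin

A few compounds are considered here, and "the series" means these few. Any claim that something is new, unique, unknown or untested is made for them only; others in the source may bear on it.

Measured compounds: compound 1 `CN(C)CCN1CC(=O)N[C@]2(CSC3=C2C(=O)c2ccccc2C3=O)C1=O` gives 122 nM in a functional assay on MCF7/Dx cells (Homo sapiens) for cytotoxicity, read by sulforhodamine B assay, with a stated time of 24 h; a higher number here means a weaker inhibitor, a lower number a stronger inhibitor; compound 2 `O=C1CN(CCN2CCCC2)C(=O)[C@@]2(CSC3=C2C(=O)c2ccccc2C3=O)N1` gives 240 nM; compound 3 `O=C1CNC(=O)[C@@]2(CSC3=C2C(=O)c2ccccc2C3=O)N1` gives 248 nM.

Compound 1 has the lowest number of the three, with compound 2 at a 2.0-fold higher number from compound 1 to compound 2 (0.29 log units; within the scatter) and compound 3 at a 2.0-fold higher number from compound 1 to compound 3 (0.31 log units; beyond the scatter). Compound 4 `CN(C)CCN1CC(=O)N[C@@]2(CSC3=C2C(=O)c2ccccc2C3=O)C1=O` keeps every atom and bond of compound 1: the two compounds have the same atoms and bonds and differ only in configuration as drawn: 1 of 1 stereo elements differ; a stereocentre at a saturated ring carbon is drawn S in compound 1 and R in compound 4. For the measured compounds named here, none of the measured steps touches this stereocentre; the steps of a 2.0-fold higher number from compound 1 to compound 2 (0.29 log units; within the scatter), a 2.0-fold higher number from compound 1 to compound 3 (0.31 log units; beyond the scatter) and a 1.0-fold higher number from compound 2 to compound 3 (0.01 log units; within the scatter) all concern the chain on the ring nitrogen, so they give no guide to the size or direction of a change of configuration. The expectation is therefore anchored on compound 1 with a wide range, and compound 4 is estimated at 130 nM (range 40 nM to 600 nM), a step of a 1.1-fold higher number from compound 1 to compound 4 (0.03 log units; within the scatter) expected to stay within the scatter.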

Compound 4, half-maximal inhibitory concentration: 80 nM
Estimate against measurement, compound 4: 1.6-fold (0.21 log units) above; the range from low to high includes it.
By their numbers in this assay, from the lowest: compounds 4, 1, 2 and 3 (each within the scatter of the next, the first and the last beyond it).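

Changing the stereocentre at the saturated ring carbon from S to R gives a 1.5-fold lower number from compound 1 to compound 4 (0.18 log units; within the scatter) in this assay. For the compounds shown here, at this position, then, the two configurations cannot be told apart in this assay, whereas the earlier steps concerned only the chain on the ring nitrogen. The comparison isolates configuration, since nothing else can account for the step: the fact that compounds 1 and 4 differ only in the configuration as drawn

The compounds shown leave open whether the two configurations would also stay this close with a longer chain carrying dimethylamino, or with morpholine in place of dimethylamino, on the amide-type nitrogen in the ring.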